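This account rests on a few compounds, and the source may have more. Where it says the series, first, only, none or still open, it means among the compounds named here.

Compound 1 `O=C1COc2ccc(-c3cnc(Cl)c(NS(=O)(=O)c4ccc(F)cc4)c3)cc2N1c1ccccc1`, compound 2 `COc1ccc(N2C(=O)COc3ccc(-c4ccc(O)cc4)cc32)cc1` and compound 3 `O=C1COc2ccc(-c3cccc(NS(=O)(=O)c4ccc(F)cc4)c3)cc2N1c1ccc(Cl)cc1` have been measured in a functional assay on MCF7 cells (Homo sapiens) for antiproliferative activity, read by MTT assay, with a stated time of 72 h; on this read-out lower numbers stand for stronger inhibition and higher numbers for weaker inhibition.

In this assay compound 1 gives > 40000 nM, which is a limit of the assay and not a number. Compound 2 gives 17300 nM in this assay. Compound 3 gives 39800 nM in this assay. Compound 1 therefore stands at the edge of what this assay can report, sitting at the limit of > 40000 nM in this assay, at which 1 of the 3 values shown sits, while compounds 2 and 3 give numbers within range.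

Compound 4 `O=C1COc2ccc(-c3cnc(Cl)c(NS(=O)(=O)c4ccc(F)cc4)c3)cc2N1C1CC1` has not yet been measured. It differs from compound 1 in one place: cyclopropyl in place of phenyl on an amide-type nitrogen in a ring. No measured pair of compounds shows what this exchange does on its own, so the size of the step cannot be read from data shown here.

Compound 4 is expected to stay weak in this assay, with an estimate of 35000 nM and a range from 8000 nM to 100000 nM. The expected step of an at least 1.1-fold lower number from compound 1 to compound 4 (0.05 log units; that floor lies within the scatter) is hard to pin down because compound 1 only reaches the limit (the limit of > 40000 nM in this assay, at which 1 of the 3 values shown sits), so a result that again falls beyond the assay's reach is a real possibility.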

Compound 4, half-maximal inhibitory concentration: 16700 nM
For compound 4 the middle estimate is 2.1-fold (0.32 log units) above the measured one; the range from low to high includes it.
By their numbers in this assay, from the lowest: compounds 4 and 2 (each within the scatter of the next); then compound 3. At a limit, above all of these: compound 1.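

In this assay, the substituent on the amide-type nitrogen in the ring proves to matter: cyclopropyl in place of phenyl gives an at least 2.3-fold lower number from compound 1 to compound 4 (0.37 log units; beyond the scatter). Within the data shown here, this is the first readable step at this position, and it shows that a phenyl is not required there for the activity seen, although compound 4 still gives only 16700 nM. For compound 1 the starting point is a limit and not a number, so the step printed is only a floor: the limit of > 40000 nM in this assay, at which 1 of the 4 values shown sits.

From the compounds shown here alone, whether a methyl, a longer chain such as butyl, or a chain ending in an amine on this nitrogen would lower the number further remains open. Compound 2 and compound 3 each differ from compound 4 in more than one place, which leaves the effect of the other parts of the molecule unresolved.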